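The source may report more compounds than this note shows. Statements on the series, on what has been measured and on what is new or still open speak of the compounds shown alone.

Measured in a physicochemical assay for metabolic stability, read by HPLC and mass spectrometry, in phosphate buffer, at 37 degrees C, at pH 7.4; on this read-out lower numbers stand for a shorter-lived compound and higher numbers for a longer-lived compound:
- compound 1 `CC(C)(O/N=C(\C(=O)N[C@@H]1C(=O)N(S(=O)(=O)O)[C@@H]1CNC(=O)CN)c1csc(N)n1)C(=O)O`: 149 h
- compound 2 `CC(C)(O/N=C(\C(=O)N[C@@H]1C(=O)N(S(=O)(=O)O)[C@@H]1Cn1cnnc1)c1csc(N)n1)C(=O)O`: 113 h
- compound 3 `CC(C)(O/N=C(\C(=O)N[C@@H]1C(=O)N(S(=O)(=O)O)[C@@H]1CN1C[C@H](CNC(=N)N)OC1=O)c1csc(N)n1)C(=O)O`: > 37 h (a limit, not a number)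

Compound 3 therefore has no exact place among these values. Compound 4 `CC(C)(O/N=C(\C(=O)N[C@@H]1C(=O)N(S(=O)(=O)O)[C@@H]1Cn1ncnc1CNC(=N)N)c1csc(N)n1)C(=O)O` differs from it by one change: a group of 10 heavy atoms (4 carbon, 6 nitrogen; one five-membered aromatic ring with 3 hetero atoms) in place of a group of 11 heavy atoms (5 carbon, 4 nitrogen, 2 oxygen; one five-membered non-aromatic ring with 2 hetero atoms), on a saturated chain carbon bound to a saturated ring carbon.

Within the data shown here, the only readable step is a 1.3-fold lower number from compound 1 to compound 2 (0.12 log units; within the scatter), which lies within the scatter. Like compound 4, compound 2 carries a five-membered aromatic ring with 3 hetero atoms at this place, and it gives 113 h. The other two steps, a step that the limit leaves unreadable from compound 1 to compound 3 and a step that the limit leaves unreadable from compound 2 to compound 3, give no size. No firm direction is therefore expected in this assay, and the estimated step is a step that the limit leaves unreadable from compound 3 to compound 4. For compound 4 the estimate is 90 h, with an expected range of 35 h to 200 h.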

Compound 4, half-life: > 37 h
Compound 4 was reported as a limit; the forecaster's own chance of this, stated with the estimate: 30%; the middle value does not contradict the limit.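

Compound 4 gives only a limit, as compound 3 does, so no new step from compound 1, compound 2 or compound 3 to compound 4 can be read: the limit of > 37 h in this assay, at which 2 of the 4 values shown sit.

The compounds shown leave open the exact half-lives of compound 3 and compound 4 in this assay, and whether either one differs from compound 1 or compound 2.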